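Serum half-life in a thymidine-azide series: the terminal ester

This account rests on a few compounds, and the source may have more. Where it says the series, first, only, none or still open, it means among the compounds named here.

Measured compounds in an ADME assay on the whole organism (serum) with Homo sapiens as the target; on this read-out higher numbers stand for a longer-lived compound and lower numbers for a shorter-lived compound:
- compound 1, `Cc1cn(C2CC(N=[N+]=[N-])C(COC(=O)NCCCC(=O)OC(C)(C)C)O2)c(=O)[nH]c1=O`: > 48 h
- compound 2, `Cc1cn(C2CC(N=[N+]=[N-])C(COC(=O)OCCCC(=O)OC(C)(C)C)O2)c(=O)[nH]c1=O`: 0.267 h
- compound 3, `Cc1cn(C2CC(N=[N+]=[N-])C(COC(=O)OCCCCCCO)O2)c(=O)[nH]c1=O`: 0.117 h

Compound 1 reaches only a limit of this assay, (the limit of > 48 h in this assay, at which 1 of the 3 values shown sits), and carries no number. Among the numbers measured, compound 2 stands highest; its nearest neighbour is compound 3, and the step of a 2.3-fold lower number from compound 2 to compound 3 (0.36 log units; beyond the scatter) is the only measured step that varies the end of the chain. That step is small and bears on the question at hand, since compound 4, `CCCCOC(=O)OCC1OC(n2cc(C)c(=O)[nH]c2=O)CC1N=[N+]=[N-]`, again changes only the chain end: methyl in place of tert-butoxycarbonyl on a saturated chain carbon, three bonds along the chain from an oxygen next to a carbonyl group. Within the data shown here, with the one measured chain-end change yielding a modest fall, and no other measured change at this position, the expectation for compound 4 is a number close to that of compound 2, with no step beyond the scatter in either direction firmly expected; the estimate is a 1.1-fold higher number from compound 2 to compound 4 (0.05 log units; within the scatter). For compound 4 the estimated value in this assay is therefore 0.3 h, expected to lie between 0.1 h and 0.9 h.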

Compound 4, half-life: 0.15 h
The estimate for compound 4 lay 2.0-fold (0.30 log units) above the measured number; the range from low to high includes it.
By their numbers in this assay, from the lowest: compounds 3, 4 and 2 (each within the scatter of the next, the first and the last beyond it). At a limit, above all of these: compound 1.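

In this assay, methyl takes the place of tert-butoxycarbonyl with a 1.8-fold lower number from compound 2 to compound 4 (0.25 log units; within the scatter), so within this pair the short half-life does not depend on the tert-butoxycarbonyl group. Hydrogen in place of 2-hydroxyethyl likewise gives a 1.3-fold higher number from compound 3 to compound 4 (0.11 log units; within the scatter), which leaves the butyl end of compound 4 within the scatter of both other chain ends, although a 2.3-fold lower number from compound 2 to compound 3 (0.36 log units; beyond the scatter) remains beyond it. Nothing on hand accounts for these steps.

Compound 1 gives a limit of the assay, > 48 h, and steps to it cannot be read. As far as these compounds go, whether a chain ending in a carboxylic acid or an amine, or a longer chain, would stay in this same range remains open.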